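Chloro in place of fluoro on the shared core

A few compounds are considered here, and "the series" means these few. Any claim that something is new, unique, unknown or untested is made for them only; others in the source may bear on it.

Compound 1 `[N-]=[N+]=N[C@@H]1C(n2ccc(=O)[nH]c2=O)[Se][C@H](CO)[C@H]1O`: in a functional assay on PC-3 cells (Homo sapiens) for cytotoxicity, read by sulforhodamine B assay (a higher number here means a weaker inhibitor, a lower number a stronger inhibitor), compound 1 gives > 100000 nM, which is a limit of the assay.
Compound 2 `Cc1cn(C2[Se][C@H](CO)[C@@H](O)[C@@H]2N=[N+]=[N-])c(=O)[nH]c1=O`: in this assay compound 2 gives > 100000 nM, a limit of the assay.
Compound 3 `[N-]=[N+]=N[C@@H]1C(n2cc(F)c(=O)[nH]c2=O)[Se][C@H](CO)[C@H]1O`: in this assay compound 3 gives > 100000 nM, again a limit of the assay.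

Compound 3 therefore stands only at a limit, and the two other values shown are limits as well; all three sit at the limit of > 100000 nM in this assay, at which 3 of the 3 values shown sit. Compound 4 `[N-]=[N+]=N[C@@H]1C(n2cc(Cl)c(=O)[nH]c2=O)[Se][C@H](CO)[C@H]1O` differs from compound 3 by chloro in place of fluoro on an aromatic carbon. For the measured compounds named here, the steps that bear on this change are a step that the two limits leave unreadable from compound 1 to compound 3 and a step that the two limits leave unreadable from compound 2 to compound 3; both are unreadable because every value involved sits at the limit of > 100000 nM in this assay, at which 3 of the 3 values shown sit. No size of step in this assay can thus be read for compound 4, in either direction, and the measured steps give no reason to expect a value away from the limit. Compound 4 is expected to give about 100000 nM in this assay, within 40000 nM to 300000 nM, so that the expected step of a number no higher from compound 3 to compound 4 (the limit leaves the size open) is not readable beyond the scatter.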

Compound 4, half-maximal inhibitory concentration: > 100000 nM
Compound 4: only a limit was reported; the forecaster's own chance of this, stated with the estimate: 85%; the middle value lies on the limit itself.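

No step from compound 1, compound 2 or compound 3 to compound 4 can be read in this assay, since every value is a limit: the limit of > 100000 nM in this assay, at which 4 of the 4 values shown sit.

The compounds shown leave open how strong any of them is in this assay, and whether any change on the shared core would bring a value off this limit.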